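A 2-Methoxyphenyl Swap in a Series at Its Limit

The source may hold more compounds than are shown below. What is called first, only, known or untested is meant among the compounds shown, and "the series" means these compounds.

Of the compounds shown here, three sharing one core have been tested in a functional assay on HeLa cells (Homo sapiens) for inhibition, read by sulforhodamine B assay; a higher number here means a weaker inhibitor, a lower number a stronger inhibitor. Compound 1 `O=C1C=C(N2CCC2)C(=O)c2c1nc1n2[C@H]2OC[C@@H](O)[C@H]2OC1` gives > 16000 nM, which is a limit and not a number. Compound 2 `O=C1C=C(NC2CCCCC2)C(=O)c2c1nc1n2[C@H]2OC[C@@H](O)[C@H]2OC1` gives > 16000 nM, also a limit. Compound 3 `O=C1C(N2CCCC2)=CC(=O)c2c1nc1n2[C@H]2OC[C@@H](O)[C@H]2OC1` gives > 16000 nM, again a limit. Compound 2 therefore has no exact value and stands with the other two at the limit of > 16000 nM in this assay, at which 3 of the 3 values shown sit.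

Among the compounds with values here, only one measured step touches compound 2, and it has no readable size: a step that the two limits leave unreadable from compound 1 to compound 2. The next compound, compound 4 `COc1ccccc1NC1=CC(=O)c2nc3n(c2C1=O)[C@H]1OC[C@@H](O)[C@H]1OC3`, has not yet been measured. It carries 2-methoxyphenyl in place of cyclohexyl on an amine nitrogen. Within the data shown here, the one measured step offers neither a size nor a direction to carry over to this change. The expectation in this assay thus rests on the shared position of the three compounds at the limit of > 16000 nM in this assay, at which 3 of the 3 values shown sit, and it is for little change, with any shift going towards stronger inhibition. The estimated step is an at least 1.3-fold lower number from compound 2 to compound 4 (0.12 log units; that floor lies within the scatter), and another limit instead of a number is quite possible. For compound 4 the estimate is 12000 nM, with an expected range from 4000 nM to 30000 nM.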

Compound 4, half-maximal inhibitory concentration: 2950 nM
Estimate against measurement, compound 4: 4.1-fold (0.61 log units) above; measured number outside the range, below it.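

In this assay, compound 4 shows that the amine nitrogen on the double-bonded ring carbon can carry a group that brings the series off its limit: the change from cyclohexyl to 2-methoxyphenyl gives an at least 5.4-fold lower number from compound 2 to compound 4 (0.73 log units; beyond the scatter). The comparison with the smaller azetidin-1-yl group at the same ring carbon gives an at least 5.4-fold lower number from compound 1 to compound 4 (0.73 log units; beyond the scatter), and as both steps start from a limit, each printed size is only a floor and the real gap may be wider. The step from compound 1 to compound 2 still cannot be read, and compound 4 now stands alone as the one exact number in the set, with the others remaining at: the limit of > 16000 nM in this assay, at which 3 of the 4 values shown sit.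

The compounds shown do not separate the aromatic ring from its methoxy group, so a plain phenyl or a 2-hydroxyphenyl on the same nitrogen would be needed to tell which of the two parts carries the change. Going by these compounds, it also remains open whether (2-methoxyphenyl)amino would give a similar number in the arrangement of the two carbonyls and the amine seen in compound 3.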